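The source may report more compounds than this note shows. Statements on the series, on what has been measured and on what is new or still open speak of the compounds shown alone.

Values in a functional assay on CHO cells for agonist activity at Alpha-1A adrenergic receptor (Homo sapiens), read by fluorescence and calcium flux (on this read-out lower numbers stand for an effect already at smaller amounts and higher numbers for an effect only at larger amounts of compound), for the measured compounds:
compound 1, `Clc1ccc2c(c1-c1cn[nH]c1)CCC2c1ncc[nH]1`: 78 nM
compound 2, `COCc1cccc2c1CC[C@H]2c1ncc[nH]1`: 37 nM
compound 3, `c1cc(Cn2cccn2)c2c(c1)[C@H](c1ncc[nH]1)CC2`: 32 nM

Compound 3 has the lowest of the three numbers, but its gap to compound 2 is within the scatter, so the two cannot be ordered; compound 1 is further off, with a number beyond the scatter from that of compound 3.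

Compound 4 is `Cc1noc(Cc2cccc3c2CC[C@H]3c2ncc[nH]2)n1`, not yet measured. It differs from compound 3 in one place: 3-methyl-1,2,4-oxadiazol-5-yl in place of 1H-pyrazol-1-yl on a saturated chain carbon bound to an aromatic carbon. Going by the values given here, only one measured step bears on this, the earlier exchange at the same saturated chain carbon, which ran a 1.2-fold lower number from compound 2 to compound 3 (0.06 log units; within the scatter) and stayed within the scatter. Among the compounds with values here, that is one step only, and it exchanged a different pair of groups, so it says little about the present pair; no compound carries the entering group. With nothing pointing either way, the expected step of a 1.3-fold higher number from compound 3 to compound 4 (0.10 log units; within the scatter) is none beyond the scatter, though the range is kept wide for want of a direct precedent. Compound 4 is therefore estimated at 40 nM, within 15 nM to 110 nM.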

Compound 4, half-maximal effective concentration in the Alpha-1A adrenergic receptor assay: 111 nM
The estimate for compound 4 lay 2.8-fold (0.44 log units) below the measured number, and the stated range ends below it.
By their numbers in the Alpha-1A adrenergic receptor assay, from the lowest: compounds 3 and 2 (each within the scatter of the next); then compounds 1 and 4 (each within the scatter of the next).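

In the Alpha-1A adrenergic receptor assay the saturated chain carbon bound to an aromatic carbon proves sensitive to the group it carries: the earlier exchange a 1.2-fold lower number from compound 2 to compound 3 (0.06 log units; within the scatter) stayed within the scatter, with compound 3 at 32 nM, whereas 3-methyl-1,2,4-oxadiazol-5-yl in place of 1H-pyrazol-1-yl gives a 3.5-fold higher number from compound 3 to compound 4 (0.54 log units; beyond the scatter), with compound 4 at 111 nM, and the same group in place of methoxy gives a 3.0-fold higher number from compound 2 to compound 4 (0.48 log units; beyond the scatter) at this place. So not every five-membered aromatic ring is tolerated here alike, although the pattern rests on compound 3 and compound 4 alone. In a physicochemical assay for lipophilicity, at pH 7.4 (a higher number here means a more lipophilic compound, a lower number a more polar compound), compound 3 gives 1.8 and compound 4 gives 2; the pyrazolyl to oxadiazolyl exchange gives a number 0.20 log units higher from compound 3 to compound 4 (within the scatter) and thus does not separate the pair on that read-out, while nothing available gives a reason for the step in agonist activity.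

Still open, going by these compounds, is whether the higher number belongs to the oxadiazole ring itself or to its methyl, which a 1,2,4-oxadiazol-5-yl without that methyl would separate. Also open, on these data alone, is how an amine or a carboxylic acid on the same carbon would read in the Alpha-1A adrenergic receptor assay and whether any such group would move the number clearly lower than the values of compound 2 and compound 3.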